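This account rests on a few compounds, and the source may have more. Where it says the series, first, only, none or still open, it means among the compounds named here.

Of the compounds shown here, three from one series have been measured in a functional assay on MGC-803 cells (Homo sapiens) for inhibition, read by MTT assay, with a stated time of 48 h (a higher number here means a weaker inhibitor, a lower number a stronger inhibitor), and a fourth awaits its number. Compound 1 `Cc1ccc(NC(=S)NC(=O)c2ccc(OCc3cccc(Cl)c3)cc2)cc1-c1nc2ccccc2[nH]1` gives 51300 nM in this assay. Compound 2 `Cc1ccc(NC(=S)NC(=O)c2ccc(OCc3ccc(C(F)(F)F)cc3)cc2)cc1-c1nc2ccccc2[nH]1` gives 6500 nM in this assay. The change from the first to the second is 4-(trifluoromethyl)phenyl in place of 3-chlorophenyl on a saturated chain carbon bound to an oxygen on an aromatic ring, and it made a 7.9-fold lower number from compound 1 to compound 2 (0.90 log units; beyond the scatter).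

Compound 3 `Cc1ccc(NC(=O)NC(=O)c2ccc(OCc3cccc(Cl)c3)cc2)cc1-c1nc2ccccc2[nH]1` gives 20800 nM in this assay, which places it between the other two: compound 1 stands higher and compound 2 lower, both gaps beyond the usual scatter. The difference between the core of compound 3 and the core of compound 1 is not broken down here.

Compound 4 `Cc1ccc(NC(=O)NC(=O)c2ccc(OCc3ccc(C(F)(F)F)cc3)cc2)cc1-c1nc2ccccc2[nH]1` has not yet been measured in this assay. It differs from compound 3 by 4-(trifluoromethyl)phenyl in place of 3-chlorophenyl on a saturated chain carbon bound to an oxygen on an aromatic ring, the same change that separates compound 1 from compound 2, made at the same place. Within the data shown here, the only guide to its effect is the one measured step, a 7.9-fold lower number from compound 1 to compound 2 (0.90 log units; beyond the scatter), and a single step on a different core is a thin basis, so the account expects a step of similar direction but allows it to be smaller. On that footing the step from compound 3 to compound 4 is estimated as a 5.9-fold lower number from compound 3 to compound 4 (0.77 log units; beyond the scatter). The resulting estimate for compound 4 in this assay is 3500 nM, with a range from 1200 nM to 10000 nM.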

Compound 4, half-maximal inhibitory concentration: 14900 nM
Estimate against measurement, compound 4: 4.3-fold (0.63 log units) below; measured number above the stated range.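

On the core of compound 3 in this assay, putting 4-(trifluoromethyl)phenyl in place of 3-chlorophenyl leaves the two values within the usual scatter of each other, at a 1.4-fold lower number from compound 3 to compound 4 (0.14 log units; within the scatter). Among these compounds, this shows that the size of the step seen on the core of compound 1 did not carry over to the core of compound 3, and that a gain measured for this change on one core cannot simply be transferred to the other, as the two steps set side by side make plain: the same change on two cores in this assay, a 7.9-fold lower number (0.90 log units; beyond the scatter) from compound 1 to compound 2 and a 1.4-fold lower number (0.14 log units; within the scatter) from compound 3 to compound 4, 5.7-fold (0.75 log units) apart, beyond the scatter of two such steps It does not show why the two cores respond differently, and with only one matched pair on each core, it does not establish a rule for any other group at this place or for any core beyond these two.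

The compounds shown leave open whether a nitrile, an amine or a carboxylic acid in place of the trifluoromethyl group would also give steps that differ between the two cores. They also leave open whether a longer chain between the oxygen and the aromatic ring would give steps that differ in the same way.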